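Adding pyridin-4-yl to the amide of compound 2

The source may report more compounds than this note shows. Statements on the series, on what has been measured and on what is new or still open speak of the compounds shown alone.

In a functional assay on the whole organism for inhibition, with Cavia porcellus as the target (on this read-out lower numbers stand for an effect already at smaller amounts and higher numbers for an effect only at larger amounts of compound), compound 1 (`CCOC(=O)CCC(=O)N1CCSC1COc1ccccc1OC`) gives 24 mg/kg and compound 2 (`CNC(=O)CC(=O)N1CCSC1COc1ccccc1OC`) gives 21 mg/kg so the two sit within the usual scatter of each other and neither can be ranked above the other. Compound 3 (`COc1ccccc1OCC1SCCN1C(=O)CC(=O)NCc1ccncc1`) follows from compound 2 through a single change (pyridin-4-yl in place of hydrogen on a saturated chain carbon bound to an amide-type nitrogen) that puts pyridin-4-yl in place of hydrogen on a saturated chain carbon bound to an amide-type nitrogen. Among the measured compounds shown here, the only measured step available is a 1.1-fold lower number from compound 1 to compound 2 (0.06 log units; within the scatter) for methylcarbamoyl in place of (ethoxycarbonyl)methyl on a saturated chain carbon bound to a carbonyl carbon. For the measured compounds named here, that is a different change from the new one, so it offers only weak guidance, and no measurement yet shows what pyridin-4-yl does here. Resting on compound 2 at 21 mg/kg and that small step, no shift beyond the scatter is expected. The expected change is a 1.5-fold lower number from compound 2 to compound 3 (0.18 log units; within the scatter) and no firm direction is claimed for it. Compound 3 is estimated at 14 mg/kg with a deliberately wide range from 4 mg/kg to 40 mg/kg on this measure.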

Compound 3, dose for half-maximal effect: 23 mg/kg
Beside the measured number, compound 3's estimate is 1.6-fold (0.22 log units) below it; the range from low to high includes it.
By their numbers in this assay, from the lowest: compounds 2, 3 and 1 (each within the scatter of the next).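

In this assay, the change from methyl to (pyridin-4-yl)methyl gives a 1.1-fold higher number from compound 2 to compound 3 (0.04 log units; within the scatter), so a group of 6 heavy atoms carrying one six-membered aromatic ring can enter on the saturated chain carbon bound to an amide-type nitrogen while the number stays within the scatter. Among the compounds shown here, the earlier step concerned a different place, a saturated chain carbon bound to a carbonyl carbon, so this is the first reading at this place, and it gives no sign that the read-out responds to this added group. No supporting measurement bears on this result.

The compounds shown leave open whether phenyl, which has no hetero atom in the ring, would read the same as pyridin-4-yl at this place, and so whether the ring nitrogen plays any part. They also leave open whether a longer chain leading to the pyridin-4-yl, or a carboxylic acid or a dimethylamino group in its place, would move the number beyond the scatter in this assay.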